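The source may report more compounds than this note shows. Statements on the series, on what has been measured and on what is new or still open speak of the compounds shown alone.

Of the compounds shown here, three with a shared core have been tested in a functional assay on T98G cells (Homo sapiens) for inhibition, read by MTT assay, with a stated time of 72 h; on this read-out lower numbers stand for stronger inhibition and higher numbers for weaker inhibition. Compound 3 `CC1(C)CC(NC(=S)Nc2ccc(Cl)cc2)c2cc(Br)ccc2O1` gives 22000 nM in this assay. Compound 1 `CC1(C)CC(NC(=S)Nc2cccc(Cl)c2)c2cc(Br)ccc2O1` gives 9000 nM in this assay, and compound 2 `CC1(C)CC(NC(=O)Nc2ccc(Cl)cc2)c2cc(Cl)ccc2O1` gives 33000 nM in this assay. The difference between the core of compound 2 and the core of compound 3 is not broken down here; the two values stand within the usual scatter of each other, so no order between them can be read.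

Compound 1 and compound 3 differ in one place only: 3-chlorophenyl in place of 4-chlorophenyl on an amide-type nitrogen. That change gave a 2.4-fold lower number from compound 3 to compound 1 (0.39 log units; beyond the scatter), a modest step but one that lies beyond the scatter.

Compound 4 `CC1(C)CC(NC(=O)Nc2cccc(Cl)c2)c2cc(Cl)ccc2O1` has not yet been measured in this assay. It differs from compound 2 in the same way: 3-chlorophenyl in place of 4-chlorophenyl on an amide-type nitrogen. The place is not identical, though: in compound 3 the nitrogen sits next to a thiocarbonyl carbon, while in compound 2 it sits next to a carbonyl carbon, so this is the same kind of change rather than the same change. Starting from compound 2, the expected step to compound 4 is a 2.4-fold lower number from compound 2 to compound 4 (0.37 log units; beyond the scatter), because a 2.4-fold lower number from compound 3 to compound 1 (0.39 log units; beyond the scatter) is the single earlier example of this kind of change and the only guide available. Compound 4 is therefore estimated to give 14000 nM in this assay, with a likely range from 6000 nM to 40000 nM. The measurement will show whether this holds.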

Compound 4, half-maximal inhibitory concentration: 25000 nM
For compound 4 the middle estimate is 1.8-fold (0.25 log units) below the measured one; the range from low to high includes it.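

In this assay, putting 3-chlorophenyl in place of 4-chlorophenyl on the core carrying the carbonyl gave a 1.3-fold lower number from compound 2 to compound 4 (0.12 log units; within the scatter), so no order between these two compounds can be read. Set beside the earlier example, the two results cannot be told apart: the same change on two cores in this assay, a 2.4-fold lower number (0.39 log units; beyond the scatter) from compound 3 to compound 1 and a 1.3-fold lower number (0.12 log units; within the scatter) from compound 2 to compound 4, 1.9-fold (0.27 log units) apart, within the scatter of two such steps. For the compounds shown here, this shows no sign that the change behaves differently on the two cores, but it does not prove that the change carries over either, since only one of the two steps lies beyond the scatter and two pairs are a very small sample.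

The compounds shown leave open how much each difference between the two cores matters, since the carbonyl and thiocarbonyl cores also carry different halogens and no pair here isolates either difference. They also leave open whether the step seen with 3-chlorophenyl and 4-chlorophenyl would look the same if another group, such as methoxy, trifluoromethyl or a nitrile, took the place of the chlorine on the phenyl ring.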